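A Ring Opened to a Diol: Estimating Compound 4

The source may report more compounds than this note shows. Statements on the series, on what has been measured and on what is new or still open speak of the compounds shown alone.

Of the compounds shown here, three have been tested so far, and none gave a measurable number. Compound 1 `Cc1ccc(-c2nc3ccc(F)cc3s2)cc1N` was run in a functional assay on THP-1 cells (Homo sapiens) for cytotoxicity, read by MTT assay, with a stated time of 2 days (on this read-out lower numbers stand for stronger inhibition and higher numbers for weaker inhibition), and returned only a limit of > 50000 nM. Compound 2 `COc1ccc2nc(-c3ccc(NC(=O)NCc4ccccc4)cc3)sc2c1` in this assay likewise stopped at a limit, > 50000 nM. Compound 3 `CC1(C)O[C@H]2O[C@H]([C@H]3COC(C)(C)O3)[C@H](OCc3ccc(-c4nc5ccc(F)cc5s4)cc3)[C@H]2O1` in this assay also reached only a limit, > 50000 nM. Compound 3 thus stands at the limit of > 50000 nM in this assay, at which 3 of the 3 values shown sit, and no ordering among the three can be drawn.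

Compound 4 `CC1(C)O[C@H]2O[C@H]([C@H](O)CO)[C@H](OCc3ccc(-c4nc5ccc(F)cc5s4)cc3)[C@H]2O1` has not yet been measured. It differs from compound 3 in one place: 1,2-dihydroxyethyl in place of 2,2-dimethyl-1,3-dioxolan-4-yl on a saturated ring carbon. Within the data shown here, no pair of measured compounds shows the effect of such a change, so nothing measured points to a step in either direction in this assay; any step is expected to stay within the scatter. Compound 4 is expected to give about 60000 nM, most likely again only a limit, within 20000 nM to 200000 nM. The step that this estimate implies, a step that the limit leaves unreadable from compound 3 to compound 4, is expected to be essentially none.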

Compound 4, half-maximal inhibitory concentration: 3000 nM
Estimate against measurement, compound 4: 20-fold (1.30 log units) above, outside the stated range (below it).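

In this assay, among these compounds, the swap of 2,2-dimethyl-1,3-dioxolan-4-yl for 1,2-dihydroxyethyl gives an at least 16-fold lower number from compound 3 to compound 4 (1.22 log units; beyond the scatter) and so yields the first measurable number in this set. Among the compounds shown here, this shows that a change at this saturated ring carbon alone can move the read-out, something the earlier compounds could not show since no pair of them differed in one place. The step gives only a minimum size because compound 3 stands at a limit: the limit of > 50000 nM in this assay, at which 3 of the 4 values shown sit.

The change removes a ring and adds 2 hydrogen-bond donors at once, and the compounds shown cannot separate these two differences. Going by these compounds, whether one hydroxyl would be enough, or whether a hydroxymethyl, an amine or a carboxylic acid on this carbon would give a similar number, also remains open.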